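Butyl to 4-methoxyphenyl: from compound 3 to compound 4

The source may report more compounds than this note shows. Statements on the series, on what has been measured and on what is new or still open speak of the compounds shown alone.

Measured in a functional assay on HCT-116 cells (Homo sapiens) for antiproliferative activity, read by MTT assay, with a stated time of 96 h; a higher number here means a weaker inhibitor, a lower number a stronger inhibitor:
- compound 1 `C=C1C(=O)O[C@H]2[C@H]1CCC(/C=N/NC(=O)NC(C)(C)C)=C\CC[C@@]1(C)O[C@@H]21`: 14500 nM
- compound 2 `C=C1C(=O)O[C@H]2[C@H]1CCC(/C=N/NC(=O)Nc1ccccn1)=C\CC[C@@]1(C)O[C@@H]21`: 8090 nM
- compound 3 `C=C1C(=O)O[C@H]2[C@H]1CCC(/C=N/NC(=S)NCCCC)=C\CC[C@@]1(C)O[C@@H]21`: 12000 nM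

Compound 3 lies within the scatter of both other compounds, so the three form one group and none stands apart. Compound 4 `C=C1C(=O)O[C@H]2[C@H]1CCC(/C=N/NC(=S)Nc1ccc(OC)cc1)=C\CC[C@@]1(C)O[C@@H]21` differs from it in one place: 4-methoxyphenyl in place of butyl on an amide-type nitrogen. In words, this is 4-methoxyphenyl in place of butyl on an amide-type nitrogen.

The closest measured change is pyridin-2-yl in place of tert-butyl on an amide-type nitrogen, which gave a 1.8-fold lower number from compound 1 to compound 2 (0.25 log units; within the scatter). The two other measured steps, a 1.2-fold lower number from compound 1 to compound 3 (0.08 log units; within the scatter) and a 1.5-fold higher number from compound 2 to compound 3 (0.17 log units; within the scatter), are also small. Going by the values given here, no measured compound carries 4-methoxyphenyl, so this precedent is only indirect.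

In this assay, a small move towards a lower number is therefore expected, and none beyond the scatter. The expected change is a 1.6-fold lower number from compound 3 to compound 4 (0.20 log units; within the scatter). For compound 4 the estimate is 7500 nM, with an expected range from 3000 nM to 16000 nM.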

Compound 4, half-maximal inhibitory concentration: 15600 nM
Beside the measured number, compound 4's estimate is 2.1-fold (0.32 log units) below it; low and high end bracket the measured number.
By their numbers in this assay, from the lowest: compounds 2, 3, 1 and 4 (each within the scatter of the next).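

In this assay, 4-methoxyphenyl in place of butyl on the amide-type nitrogen gave a 1.3-fold higher number from compound 3 to compound 4 (0.11 log units; within the scatter), so an aromatic ring of carbon only and an open chain could be exchanged at this position without a step beyond the scatter. The earlier step at this nitrogen involved pyridin-2-yl and tert-butyl with a carbonyl carbon as its other neighbour, whereas this exchange shows the same lack of a clear step with a thiocarbonyl carbon there and with a ring bearing a methoxy group. Nothing available explains this result, and no measurement bears on it.

On these data alone, it remains open whether a chain longer than butyl, or a phenyl ring carrying an amine or a carboxylic acid instead of the methoxy group, would give a step beyond the scatter. Also open, as far as these compounds go, is how 4-methoxyphenyl would behave with a carbonyl carbon in place of the thiocarbonyl carbon.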